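The source may report more compounds than this note shows. Statements on the series, on what has been measured and on what is new or still open speak of the compounds shown alone.

Compounds measured in a functional assay on MCF7 cells (Homo sapiens) for antiproliferative activity, read by CCK-8 assay, with a stated time of 48 h (on this read-out higher numbers stand for weaker inhibition and lower numbers for stronger inhibition), so far:

compound 1 `Cc1ccc(-c2[nH]c3ccccc3c2C2=C(Br)C(=O)C(Br)=C(Br)C2=O)cc1` — compound 1: > 25 ug/mL
compound 2 `Cc1ccc(-c2[nH]c3ccccc3c2C2=C(Cl)C(=O)C(c3c(C)[nH]c4ccccc34)=C(Cl)C2=O)cc1` — compound 2: 2.8 ug/mL
compound 3 `Cc1[nH]c2ccccc2c1C1=C(Cl)C(=O)C(Cl)=C(c2c(-c3ccccc3)[nH]c3ccccc23)C1=O` — compound 3: 2.58 ug/mL

The value of compound 1 in this assay is a limit of the assay, not a number. Of the two numbers, compound 3 in this assay gives 2.58 ug/mL and compound 2 gives 2.8 ug/mL; the two sit within the scatter of each other, so no order between them can be read from the data. Going by the values given here, no pair of the measured compounds differs in a single place, so no measured step is available on which to rest a prediction.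

Compound 4 `Cc1ccc(-c2[nH]c3ccccc3c2C2=C(Cl)C(=O)C(Cl)=C(c3c(C)[nH]c4ccccc34)C2=O)cc1` is not yet measured. It differs from compound 3 by methyl in place of hydrogen on an aromatic carbon, that is, the change reads phenyl to 4-methylphenyl. Compound 2 already carries a 4-methylphenyl on the same kind of core and gives 2.8 ug/mL in this assay, so the expected step of a 1.1-fold higher number from compound 3 to compound 4 (0.04 log units; within the scatter) is none beyond the scatter. Compound 4 is therefore estimated at 2.8 ug/mL in this assay, within 1.2 ug/mL to 6.5 ug/mL.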

Compound 4, half-maximal inhibitory concentration: 2.88 ug/mL
Compound 4: middle estimate off by 1.0-fold (0.01 log units), on the low side, and the stated range covers the measured number.
By their numbers in this assay, from the lowest: compounds 3, 2 and 4 (each within the scatter of the next). At a limit, above all of these: compound 1.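

Going by these compounds alone, the change from phenyl to 4-methylphenyl, methyl in place of hydrogen on an aromatic carbon, gives in this assay the first step that can be read at a single place: a 1.1-fold higher number from compound 3 to compound 4 (0.05 log units; within the scatter) on this pair. The earlier compounds shown here offered no such pair, and this one shows that at this position, para to a large group, methyl leaves the number within the scatter of the hydrogen compound. Nothing at hand bears on the reason for the size of this step.

Going by these compounds, whether this position would respond in the same way to a group other than methyl, such as an amine, a carboxylic acid or a longer chain, stays open. On these data alone, compound 1, whose > 25 ug/mL is a limit of the assay and not a number, differs from the other compounds in more than one place, so which of its differences goes with that limit also stays open.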